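Hydroxy for carboxy on the amino acid arm

The source may hold more compounds than are shown below. What is called first, only, known or untested is meant among the compounds shown, and "the series" means these compounds.

Measured compounds:
compound 1 `C[C@H](NC(=O)CN(c1nc(Cl)nc2[nH]cnc12)C1CC1)C(=O)O` — 14.7%
compound 2 `O=C(O)CC[C@H](NC(=O)CN(c1nc(Cl)nc2[nH]cnc12)C1CC1)C(=O)O` — 29.5%
compound 3 `O=C(O)C[C@H](NC(=O)CN(c1nc(Cl)nc2[nH]cnc12)C1CC1)C(=O)O` — 11.6%

In a functional assay on the whole organism (Tail, strain ICR) with Mus musculus as the target, in the tail flick test, with a stated time of 150 min, at a dose of 25 umol/kg by the oral route (on this read-out higher numbers stand for a stronger effect at the one dose given and lower numbers for a weaker effect), compound 3 gives 11.6%, and compound 1 cannot be told apart from it, since a number 3.1 percentage points lower from compound 1 to compound 3 (within the scatter). Compound 2 stands beyond the scatter above both, as a number 17.9 percentage points lower from compound 2 to compound 3 (beyond the scatter) and a number 14.8 percentage points higher from compound 1 to compound 2 (beyond the scatter) show.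

Compound 4 `O=C(CN(c1nc(Cl)nc2[nH]cnc12)C1CC1)N[C@@H](CO)C(=O)O` differs from compound 3 by hydroxy in place of carboxy on a saturated chain carbon, two bonds along the chain from an amide-type nitrogen and a carbonyl carbon. The step that bears most on this is a number 3.1 percentage points lower from compound 1 to compound 3 (within the scatter), which shows that carboxy in place of hydrogen at this carbon changed nothing beyond the scatter; only carboxymethyl at that place, in a number 17.9 percentage points lower from compound 2 to compound 3 (beyond the scatter), moved the number modestly. A hydroxy group at this carbon is not yet covered by any measured pair. The step of a number 3.4 percentage points higher from compound 3 to compound 4 (within the scatter) is therefore expected to stay within the scatter, with at most a small rise. For compound 4 the estimate is 15%, ranging from 5% to 28%.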

Compound 4, a percentage reported as activity, at one dose (the size of the read-out at that dose, not a potency): 18.8%
The estimate for compound 4 lay 3.8 percentage points below the measured number, within the range that was stated.
By their numbers in this assay, from the lowest: compounds 3, 1 and 4 (each within the scatter of the next); then compound 2.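

Hydroxy at this carbon gives no separation from carboxy or hydrogen in this assay (in a number 7.2 percentage points higher from compound 3 to compound 4 (within the scatter) and a number 4.1 percentage points higher from compound 1 to compound 4 (within the scatter)). Carboxymethyl alone stays apart from the other groups at this place, now also from hydroxy (in a number 10.7 percentage points lower from compound 2 to compound 4 (beyond the scatter)). No measurement shown explains these differences.

As far as these compounds go, it remains open whether the carboxymethyl result depends on the chain or on its end group, which a 2-hydroxyethyl or plain ethyl group at this carbon would help separate. From the compounds shown here alone, the result with an amine here also remains open.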